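Compound 4: iodo in place of furan-2-yl

A few compounds are considered here, and "the series" means these few. Any claim that something is new, unique, unknown or untested is made for them only; others in the source may bear on it.

Values so far in an ADME assay on Caco-2 cells (Homo sapiens) for permeability, read by LC-MS, in the apical to basolateral direction, with a stated time of 90 min (a higher number here means that the compound crosses the layer faster, a lower number that the compound crosses the layer more slowly), for this series
- compound 1 `Cc1cc(-n2cccn2)cc(C(=O)NNS(=O)(=O)c2ccccc2)c1F` gives 48 10^-6 cm/s
- compound 2 `CCCOc1cccc(C(=O)NNS(=O)(=O)c2ccccc2F)c1` gives 77.3 10^-6 cm/s
- compound 3 `O=C(NNS(=O)(=O)c1ccccc1F)c1cccc(-c2ccco2)c1` gives 55.3 10^-6 cm/s

Compound 3 at 55.3 10^-6 cm/s sits within the scatter of both compound 1 and compound 2, so it is a reasonable reference point for the next reading. Compound 4 `O=C(NNS(=O)(=O)c1ccccc1F)c1cccc(I)c1` carries iodo in place of furan-2-yl on an aromatic carbon on an aromatic carbon of a six-membered aromatic ring of carbon only, meta to a large group.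

Going by the values given here, no measured compound in the set carries iodo, so this change has not itself been seen. Among the compounds with values here, no measured step links compound 1 to the other compounds. One measured step involves the group that leaves: a 1.4-fold lower number from compound 2 to compound 3 (0.15 log units; within the scatter) with furan-2-yl in place of propoxy on an aromatic carbon. That step stays within the scatter, but it is a single pair and a thin guide.

Given the step of a 1.4-fold lower number from compound 2 to compound 3 (0.15 log units; within the scatter) as the only evidence, no step beyond the scatter is expected in this assay and neither direction is favoured. The estimated step is a 1.0-fold higher number from compound 3 to compound 4 (0.02 log units; within the scatter) and it is expected to stay within the scatter. For compound 4 the estimated value is 58 10^-6 cm/s with an expected range from 32 10^-6 cm/s to 95 10^-6 cm/s for now.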

Compound 4, apparent permeability: 60.4 10^-6 cm/s
Compound 4: the middle estimate sits 1.0-fold (0.02 log units) below what was measured; measured number inside the range.
By their numbers in this assay, from the lowest: compounds 1, 3, 4 and 2 (each within the scatter of the next).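

In this assay, the aromatic carbon that carried furan-2-yl also accepts iodo, with the group going from 5 heavy atoms and a five-membered aromatic ring to 1 heavy atom and no ring, and the result is a 1.1-fold higher number from compound 3 to compound 4 (0.04 log units; within the scatter). With propoxy at the same place as the comparison, the reading is a 1.3-fold lower number from compound 2 to compound 4 (0.11 log units; within the scatter), so propoxy, furan-2-yl and iodo all lie within the scatter of one another on this shared core. Removing the ring and the hydrogen-bond acceptor of furan-2-yl therefore gives no reading beyond the scatter, and no supporting data bear on the reason for this.

As far as these compounds go, whether any group at this place can move the number beyond the scatter remains open, and an amine, a carboxylic acid or a longer alkoxy chain would be a sharper test than the three groups seen so far. Going by these compounds alone, compound 1, at 48 10^-6 cm/s, remains linked to the others by no single-place step, so the contribution of the differences in its core cannot be read.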